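The source may hold more compounds than are shown below. What is called first, only, known or untested is meant among the compounds shown, and "the series" means these compounds.

Compound 1 `CSc1nc(N)c2ncn(C3C(O)C(O)[C@@]4(COP(=O)(O)OP(=O)(O)OP(=O)(O)O)C[C@@H]34)c2n1` and compound 2 `Nc1nc(Cl)nc2c1ncn2C1C(O)C(O)[C@@]2(COP(=O)(O)OP(=O)(O)OP(=O)(O)O)C[C@@H]12` were both tested in an assay on cell membranes for activation of P2Y purinoceptor 1 (Meleagris gallopavo); on this read-out higher numbers stand for an effect only at larger amounts of compound and lower numbers for an effect already at smaller amounts; compound 1 gives 3.7 nM and compound 2 gives 3 nM. For the measured compounds named here, the only step between them, a 1.2-fold lower number from compound 1 to compound 2 (0.09 log units; within the scatter), lies within the scatter, so compound 2 stands lowest of the two numbers but not separated from compound 1. Compound 3 `CNc1ncnc2c1ncn2C1C(O)C(O)[C@@]2(COP(=O)(O)OP(=O)(O)OP(=O)(O)O)C[C@@H]12` differs from compound 2 by a group of 11 heavy atoms (6 carbon, 5 nitrogen; one five-membered aromatic ring with 2 hetero atoms, one six-membered aromatic ring with 2 hetero atoms) in place of a group of 11 heavy atoms (5 carbon, 5 nitrogen, 1 chlorine; one five-membered aromatic ring with 2 hetero atoms, one six-membered aromatic ring with 2 hetero atoms), on a saturated ring carbon. Going by the values given here, no measured step changes this part of the molecule in the same way, so the one step available gives little guidance. Compound 3 is therefore estimated at 6 nM (range 2 nM to 20 nM), a step of a 2.0-fold higher number from compound 2 to compound 3 (0.30 log units; within the scatter) that is expected to stay within the scatter.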

Compound 3, half-maximal effective concentration: 92 nM
Beside the measured number, compound 3's estimate is 15-fold (1.19 log units) below it, outside the stated range (above it).
By their numbers in this assay, from the lowest: compounds 2 and 1 (each within the scatter of the next); then compound 3.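

In this assay, the group on the saturated ring carbon turns out to be sensitive to change: replacing the chlorine-bearing group with one that has no chlorine and one more carbon gives a 31-fold higher number from compound 2 to compound 3 (1.49 log units; beyond the scatter). The earlier swap of methylsulfanyl for chloro, a 1.2-fold lower number from compound 1 to compound 2 (0.09 log units; within the scatter), gave no sign of this. Nothing available explains the size of this step. Still open, on these data alone, is whether losing the chlorine or gaining the carbon accounts for the step. It is also unknown whether a bromine atom or a methoxy group in place of the chlorine would keep the number low.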